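Sulfur substituent variation in a cytotoxicity series

This account rests on a few compounds, and the source may have more. Where it says the series, first, only, none or still open, it means among the compounds named here.

Within the data shown here, compound 1 `CC1=CCC[C@H]2[C@](C)(CC3=CC(=O)C(SC(C)(C)C)=CC3=O)[C@@H](C)CC[C@]12C` gives 37000 nM in a functional assay on HeLa cells (Homo sapiens) for cytotoxicity (on this read-out lower numbers stand for stronger inhibition and higher numbers for weaker inhibition), the lowest of the two numbers measured so far. Among the measured compounds shown here, compound 2 `CCCSC1=CC(=O)C(C[C@]2(C)[C@@H](C)CC[C@]3(C)C(C)=CCC[C@@H]23)=CC1=O` gives 97000 nM in this assay; the only measured step, a 2.6-fold higher number from compound 1 to compound 2 (0.42 log units; beyond the scatter), covers propyl in place of tert-butyl on a sulfur. Compound 3 `CC1=CCC[C@H]2[C@](C)(CC3=CC(=O)C(Sc4ccccc4)=CC3=O)[C@@H](C)CC[C@]12C` carries the change (phenyl in place of tert-butyl on a sulfur). For the measured compounds named here, only the step from compound 1 to compound 2 bears on it, and that step was modest. A step of similar or smaller size is expected here, with no clear direction, so compound 3 is estimated at 40000 nM (range 15000 nM to 110000 nM), meaning an expected 1.1-fold higher number from compound 1 to compound 3 (0.03 log units; within the scatter).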

Compound 3, half-maximal inhibitory concentration: 45000 nM
The estimate for compound 3 lay 1.1-fold (0.05 log units) below the measured number; measured number inside the range.
By their numbers in this assay, from the lowest: compounds 1 and 3 (each within the scatter of the next); then compound 2.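

Phenyl on this sulfur performs like tert-butyl in this assay (a 1.2-fold higher number from compound 1 to compound 3 (0.09 log units; within the scatter)), so a six-membered aromatic ring is tolerated here with no separation from the tert-butyl compound. Among these compounds, replacing propyl with phenyl gives a 2.2-fold lower number from compound 2 to compound 3 (0.33 log units; beyond the scatter), leaving compound 2 as the one compound apart from the other two, which shows that an unbranched chain, not an aromatic ring, marks the difference within these three compounds. Nothing available explains these differences.

As far as these compounds go, whether an amine, a carboxylic acid or a longer chain on this sulfur would shift the number remains open. Also open, from the compounds shown here alone, is whether a phenyl carrying a methoxy group or a chlorine would stay with compounds 1 and 3.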